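Methoxy on the anilino ring: compound 3 from compound 1

A few compounds are considered here, and "the series" means these few. Any claim that something is new, unique, unknown or untested is made for them only; others in the source may bear on it.

Among the measured compounds shown here, compound 1 `Cc1nc(SCC(=O)Nc2nc(-c3ccc(Cl)cc3)cs2)n(Nc2ccccc2)c1C` is the only member with a number: in a functional assay on MDA-MB-231 cells (Homo sapiens) for antiproliferative activity, read by sulforhodamine B assay, with a stated time of 48 h (on this read-out lower numbers stand for higher toxicity in this test and higher numbers for lower toxicity in this test), compound 1 gives 57800 nM. Compound 2 `Cc1ccc(Nn2c(SCC(=O)Nc3nc(-c4ccccc4)cs3)nc(C)c2C)cc1` gives > 100000 nM, which is a limit of the assay rather than a number. Of the two values shown, one sits at the limit of > 100000 nM in this assay, at which 1 of the 2 values shown sits. Compound 3 `COc1ccc(Nn2c(SCC(=O)Nc3nc(-c4ccc(Cl)cc4)cs3)nc(C)c2C)cc1` differs from compound 1 by methoxy in place of hydrogen on an aromatic carbon, para to a large group. For the measured compounds named here, no measured pair isolates this change. The step expected here is a 1.2-fold higher number from compound 1 to compound 3 (0.08 log units; within the scatter), small, if anything toward weaker, and not clearly beyond the scatter. Compound 3 is therefore estimated at 70000 nM, within 30000 nM to 150000 nM, with a fair chance that only a limit is reported.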

Compound 3, concentration lethal to 50% of the cells: > 100000 nM
Compound 3 was reported as a limit; the forecaster's own chance of this, stated with the estimate: 35%; middle value at least 1.4-fold (0.15 log units) from the limit.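

In this assay compound 3 gives only a limit, not a number. Methoxy in place of hydrogen on the anilino ring, para to a large group, gives an at least 1.7-fold higher number from compound 1 to compound 3 (0.23 log units; that floor lies within the scatter), so this change brings no lower number, and the true size of the step stays unread. With this result, most of the set sits at the top of the measurable range: the limit of > 100000 nM in this assay, at which 2 of the 3 values shown sit.

On these data alone, whether fluorine, an amine or a carboxylic acid at this position would give a lower number than compound 1 stays open. Among the compounds shown here, compound 1 remains the only compound here with a number.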